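The source may report more compounds than this note shows. Statements on the series, on what has been measured and on what is new or still open speak of the compounds shown alone.

Of the compounds shown here, three built on one shared core have been measured in a functional assay on the whole organism (strain Jcl:SD) for inhibition, with Rattus norvegicus as the target, with stated times of 3 min and 3 h, at a dose of 1 mg/kg by the intravenous route; on this read-out lower numbers stand for less inhibition and higher numbers for more inhibition at the one dose given (going by the name of the read-out). Compound 1 `CNCc1cc(-c2cccnc2F)n(S(=O)(=O)c2cccs2)c1` gives 96% in this assay. Compound 2 `CNCc1cc(-c2cccnc2F)n(S(=O)(=O)c2cccnc2)c1` gives 96%, and compound 3 `CNCc1cc(-c2cccnc2F)n(S(=O)(=O)c2ccc(OC)nc2)c1` gives 97%. The three numbers sit close together: no change at the digits printed from compound 1 to compound 2 (within the scatter), a number 1 percentage points higher from compound 1 to compound 3 (within the scatter), and a number 1 percentage points higher from compound 2 to compound 3 (within the scatter). Compound 2 therefore stands level with compound 1, the two of them together the lowest of the three numbers, with compound 3 as its furthest neighbour, though even that gap lies within the scatter.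

Compound 4 `CNCc1cn(S(=O)(=O)c2cccnc2)c(-c2cccnc2F)c1Cl` has not yet been measured. It differs from compound 2 in one place: chloro in place of hydrogen on an aromatic carbon. Among the compounds with values here, none of the measured steps touches that aromatic carbon; each of them exchanges the ring on the sulfonyl sulfur or puts methoxy in place of hydrogen on an aromatic carbon of that ring, and all of them stayed within the scatter. So no measured step bears directly on this change, and nothing among the three numbers points to a move beyond the scatter. The expectation for compound 4 in this assay is a step of a number 1 percentage points lower from compound 2 to compound 4 (within the scatter). Compound 4 is thus estimated at 95%, with a range from 85% to 99%.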

Compound 4, a percentage reported as inhibition, in the whole organism at one dose (the size of the read-out at that dose, not a potency): 95%
The estimate for compound 4 equals the measured number at the digits printed; measured number inside the range.
By their numbers in this assay, from the lowest: compounds 4, 1, 2 and 3 (each within the scatter of the next).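

Chloro in place of hydrogen, on an aromatic carbon of the five-membered aromatic ring with 1 nitrogen, changes the shared core itself, whereas the earlier steps touched only the ring on the sulfonyl sulfur. In this assay the result is a number 1 percentage points lower from compound 2 to compound 4 (within the scatter) and so a single chlorine on this carbon, next to the ring atom that bears a (methylamino)methyl group and next to the ring atom that bears a 2-fluoropyridin-3-yl group, keeps the read-out within the scatter at the one dose given. Nothing measured here explains this result.

As far as these compounds go, a read-out at one dose is not a potency, so whether compound 2 and compound 4 would still match at lower doses remains open. Also open, from the compounds shown here alone, is whether a methyl group, a nitrile or a carboxylic acid on the same carbon would stay within the scatter, and whether chloro would do the same with thiophen-2-yl or 6-methoxypyridin-3-yl on the sulfonyl sulfur.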